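Five-membered core series: ring-substituent changes and FAAH inhibition

The source may hold more compounds than are shown below. What is called first, only, known or untested is meant among the compounds shown, and "the series" means these compounds.

Measured so far, with numbers from an assay (Rattus norvegicus) for inhibition of Fatty-acid amide hydrolase 1 (Homo sapiens); on this read-out higher numbers stand for weaker inhibition and lower numbers for stronger inhibition:
- compound 1 `O=C(CCCCCCc1ccccc1)c1ncc(-c2ccc([N+](=O)[O-])cc2)o1` gives 50 nM
- compound 2 `NC(=O)c1cccc(-c2cnc(C(=O)CCCCCCc3ccccc3)o2)n1` gives 1 nM
- compound 3 `CC(=O)c1cnc(C(=O)CCCCCCc2ccccc2)o1` gives 2 nM

Compound 3 stands second highest of the three numbers. Its nearest neighbour is compound 2, where the step of a 2.0-fold higher number from compound 2 to compound 3 (0.30 log units; within the scatter) lies within the scatter, so the two cannot be ordered. Its furthest is compound 1, and the step of a 25-fold lower number from compound 1 to compound 3 (1.40 log units; beyond the scatter) is large and beyond the scatter. The related step of a 50-fold lower number from compound 1 to compound 2 (1.70 log units; beyond the scatter) is also large.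

The next compound, compound 4 `O=C(CCCCCCc1ccccc1)c1ncc(-c2cc(=O)[nH]c(=O)[nH]2)o1`, differs from compound 3 in one place: a group of 8 heavy atoms (4 carbon, 2 nitrogen, 2 oxygen; one six-membered aromatic ring with 2 hetero atoms) in place of a group of 3 heavy atoms (2 carbon, 1 oxygen; no ring), on an aromatic carbon.

For the measured compounds named here, no measured step swaps the acetyl for a ring, so no step bears directly on this change. What the data do show is that both the acetyl of compound 3 and the 6-carbamoylpyridin-2-yl of compound 2 give low numbers in this assay, while the 4-nitrophenyl of compound 1 gives a much higher one. The incoming group is a ring carrying hydrogen-bond donors and acceptors, which puts it closer in kind to compound 2 than to compound 1. The expectation is therefore a step of a 1.5-fold higher number from compound 3 to compound 4 (0.18 log units; within the scatter), not beyond the scatter, with a wide range in either direction. Compound 4 is estimated at 3 nM, from 0.5 nM to 20 nM.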

Compound 4, inhibition constant: 12 nM
Compound 4: middle estimate off by 4.0-fold (0.60 log units), on the low side, and the stated range covers the measured number.
By their numbers in this assay, from the lowest: compounds 2 and 3 (each within the scatter of the next); then compound 4; then compound 1.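

In this assay, a six-membered aromatic ring at this position does not by itself settle the number: a 12-fold higher number from compound 2 to compound 4 (1.08 log units; beyond the scatter) is large, while a 4.2-fold lower number from compound 1 to compound 4 (0.62 log units; beyond the scatter) is modest, so three ring-bearing groups on the same carbon now give three separated results. Until now the position had shown two quite different groups, the acetyl and the 6-carbamoylpyridin-2-yl, at values within the scatter of each other, but a 6.0-fold higher number from compound 3 to compound 4 (0.78 log units; beyond the scatter) is modest and beyond the scatter, so a ring with hydrogen-bond donors does not automatically keep the low number of those two compounds. Nothing at hand accounts for the order of these ring-bearing groups.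

Open, as far as these compounds go, is which part of each entering ring sets its number, and an unsubstituted pyridin-2-yl or a 6-carboxypyridin-2-yl on the shared core would help separate the ring itself from its substituent. Also open, from the compounds shown here alone, is how far the low values extend among small groups at this carbon, where a nitrile or a methyl ester would test whether the acetyl result carries over to other small non-ring groups.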